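Turning a Drawn Z Double Bond to E

The source may hold more compounds than are shown below. What is called first, only, known or untested is meant among the compounds shown, and "the series" means these compounds.

Of the compounds shown here, two have so far been tested in a functional assay on HeLa cells (Homo sapiens) for cytotoxicity, read by sulforhodamine B assay, with a stated time of 48 h; a higher number here means a weaker inhibitor, a lower number a stronger inhibitor. Compound 1, with structure `CC(=O)OC[C@H]1O[C@@H](n2cc(Cn3cc(C(C)=O)c4ccccc43)nn2)[C@H](OC(C)=O)[C@@H](OC(C)=O)[C@@H]1OC(C)=O`, gives only a limit of the assay, > 200000 nM. Going by the values given here, compound 2, with structure `CC(=O)OC[C@H]1O[C@@H](n2cc(CN3C(=O)/C(=C\c4ccccc4)c4ccccc43)nn2)[C@H](OC(C)=O)[C@@H](OC(C)=O)[C@@H]1OC(C)=O`, gives 33300 nM in this assay, and this is the only measured number in the set, so nothing ranks it against another number. Compound 3, with structure `CC(=O)OC[C@H]1O[C@@H](n2cc(CN3C(=O)/C(=C/c4ccccc4)c4ccccc43)nn2)[C@H](OC(C)=O)[C@@H](OC(C)=O)[C@@H]1OC(C)=O`, has not been measured yet. It differs from compound 2 in one respect: the two compounds have the same atoms and bonds and differ only in configuration as drawn: 1 of 6 stereo elements differ; a double bond is drawn Z in compound 2 and E in compound 3. Among the compounds with values here, no measured pair in the set shows what such a swap of drawn double-bond geometry does, so the size of the step can only be estimated. The step expected here, a 1.2-fold higher number from compound 2 to compound 3 (0.08 log units; within the scatter), is taken as modest, possibly within the scatter of this assay, in no firm direction. For compound 3 the expected value is 40000 nM, with a range from 10000 nM to 160000 nM.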

Compound 3, half-maximal inhibitory concentration: 37100 nM
Estimate against measurement, compound 3: 1.1-fold (0.03 log units) above, within the range that was stated.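

In this assay the swap of drawn double-bond geometry gives a 1.1-fold higher number from compound 2 to compound 3 (0.05 log units; within the scatter), so the Z and E forms cannot be told apart here. Going by these compounds alone, until now, no measured pair in the set isolated a single change, so the effect of this double bond's drawn geometry on the number was unknown. This pair offers a clean reading of that one feature, with nothing else altered in the structure: the fact that compounds 2 and 3 differ only in the configuration as drawn.

Still open, on these data alone, is whether an amine or a carboxylic acid placed on the shared core would shift the number beyond the scatter of this assay. As far as these compounds go, it is also open whether the same swap of geometry would again stay within the scatter on a core bearing such a group, or in a different cell line.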